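Methoxy for chloro on the amide-bearing ring

The source may report more compounds than this note shows. Statements on the series, on what has been measured and on what is new or still open speak of the compounds shown alone.

compound 1 `O=C(O)c1ccc(/C=C/c2ccc(Cl)cc2)cn1`: 150000 nM
compound 2 `O=C(Nc1ccccc1Cl)c1ccc(C(=O)O)nc1`: 16300 nM
compound 3 `O=C(Nc1ccc(F)cc1)c1ccc(C(=O)O)nc1`: 16100 nM

In an assay on isolated protein (Gallus gallus) for inhibition of transmembrane prolyl 4-hydroxylase (Homo sapiens) (on this read-out lower numbers stand for stronger inhibition and higher numbers for weaker inhibition), compound 2 gives 16300 nM, the second highest of the three numbers. Compound 3 lies within the scatter of compound 2, so the two are read as equivalent. Compound 1 stands at a higher number, beyond the scatter, and is the weakest inhibitor of the three.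

Compound 4 `COc1ccccc1NC(=O)c1ccc(C(=O)O)nc1` has not been measured. It differs from compound 2 in one place: methoxy in place of chloro on an aromatic carbon. Among the compounds with values here, no measured pair shows this exchange, so nothing fixes its direction. The change from compound 2 is expected to produce a step of a 1.1-fold higher number from compound 2 to compound 4 (0.04 log units; within the scatter), that is, none beyond the scatter. Compound 4 is therefore estimated at 18000 nM, with a range from 6000 nM to 55000 nM.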

Compound 4, half-maximal inhibitory concentration: 14800 nM
Compound 4: the middle estimate sits 1.2-fold (0.09 log units) above what was measured; measured number inside the range.
By their numbers in this assay, from the lowest: compounds 4, 3 and 2 (each within the scatter of the next); then compound 1.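

In this assay, within the data shown here, methoxy in place of chloro on an aromatic carbon ortho to a large group gives a 1.1-fold lower number from compound 2 to compound 4 (0.04 log units; within the scatter) and provides the first measured exchange at this position. At this position, the larger methoxy, with its one hydrogen-bond acceptor, therefore gives a number equivalent to that of chloro. No measured data on these compounds bear on why the two groups read alike.

Still open, as far as these compounds go, is whether an amine or a longer chain such as ethoxy on this carbon would also stay within the scatter. From the compounds shown here alone, the same exchange on other carbons of this ring also remains open.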